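The compounds below may be only part of what the source reports. "The series", "measured", "known", "first", "only" and "open" are said of these compounds alone.

Within the data shown here, compound 1 `CCc1ccc2oc(-c3ccc(NC(=O)Nc4cccc(Cl)c4)cc3Cl)cc(=O)c2c1` is one of two compounds measured in a functional assay on HCT-116 cells (Homo sapiens) for inhibition, read by MTT assay, with a stated time of 48 h; a lower number here means a stronger inhibitor, a higher number a weaker inhibitor; in this assay compound 1 gives 27900 nM, the highest of the two numbers. Among the measured compounds shown here, its only neighbour is compound 2 `COc1ccc2oc(-c3ccc(NC(=O)Nc4cccc(Cl)c4)cc3Cl)cc(=O)c2c1`, which in this assay gives 9600 nM; the step of a 2.9-fold lower number from compound 1 to compound 2 (0.46 log units; beyond the scatter) comes from methoxy in place of ethyl on an aromatic carbon. Compound 3 `CCc1ccc2oc(-c3ccc(NC(=O)Nc4ccc(Cl)cc4)cc3Cl)cc(=O)c2c1` has not yet been measured in this assay. It differs from compound 1 by 4-chlorophenyl in place of 3-chlorophenyl on an amide-type nitrogen, the two having the same atoms joined differently. For the measured compounds named here, no measured step touches the 3-chlorophenyl group, so the one known step, which alters a different part of the shared core, offers no guide to this change. Compound 3 is therefore expected to stay close to compound 1, with an estimated step of a 1.0-fold higher number from compound 1 to compound 3 (0.00 log units; within the scatter) that need not exceed the scatter. The estimate for compound 3 in this assay is 28000 nM, within a range from 8000 nM to 90000 nM.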

Compound 3, half-maximal inhibitory concentration: 28700 nM
Estimate against measurement, compound 3: 1.0-fold (0.01 log units) below; low and high end bracket the measured number.
By their numbers in this assay, from the lowest: compound 2; then compounds 1 and 3 (each within the scatter of the next).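

Among these compounds, compound 3 is the first compound to show a change on the amide-type nitrogen, and in this assay the swap of 3-chlorophenyl for 4-chlorophenyl gives a 1.0-fold higher number from compound 1 to compound 3 (0.01 log units; within the scatter). At this position, with the ethyl group kept, the two chlorophenyl isomers therefore cannot be told apart, whereas the change on the shared core gave a 2.9-fold lower number from compound 1 to compound 2 (0.46 log units; beyond the scatter), a step beyond the scatter. No measurement at hand bears on why the isomer swap leaves the number within the scatter.

The compounds shown leave open whether the same swap would also stay within the scatter in the methoxy compound 2. They also leave open whether a phenyl without chlorine, or one carrying an amine or a carboxylic acid, would move the number on this nitrogen.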